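Moving a fluorine and adding a methyl: solubility outlook

A few compounds are considered here, and "the series" means these few. Any claim that something is new, unique, unknown or untested is made for them only; others in the source may bear on it.

Of the compounds shown here, two share a fused core and have been measured in a physicochemical assay for solubility, read by HPLC, using the shake flask method, measured as kinetic solubility, with a stated time of 2 h, at pH 7.4; on this read-out higher numbers stand for higher solubility and lower numbers for lower solubility. Compound 1, `Cc1cc(N(C)Cc2ccccn2)n2nc(C)c(-c3ccccc3)c2n1`, gives 17500 nM in this assay. Compound 2, `Cc1cc(NCc2ccccn2)n2ncc(-c3ccccc3F)c2n1`, gives 5000 nM in this assay, the lower of the two numbers, and the gap to compound 1 lies beyond the scatter of the measurement.

Compound 3, `Cc1cc(NCc2ccccn2)n2ncc(-c3ccc(F)cc3C)c2n1`, has not yet been measured. Compared with compound 2, it differs in one place: 4-fluoro-2-methylphenyl in place of 2-fluorophenyl on an aromatic carbon. The group that enters has 8 heavy atoms where the group that leaves has 7; neither group carries hydrogen-bond donors, acceptors or charge.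

For the measured compounds named here, no pair of measured compounds shows this exact change, so the expectation rests only on compound 2 and the nature of the swap. A small loss of solubility is expected, and the step from compound 2 to compound 3 is estimated at a 1.7-fold lower number from compound 2 to compound 3 (0.22 log units; within the scatter), a change around the edge of the scatter. Compound 3 is therefore expected to give about 3000 nM in this assay, within a range from 1000 nM to 9000 nM.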

Compound 3, solubility: 42300 nM
Estimate against measurement, compound 3: 14-fold (1.15 log units) below, outside the stated range (above it).
By their numbers in this assay, from the lowest: compound 2; then compound 1; then compound 3.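

On the aromatic carbon of the five-membered aromatic ring, 4-fluoro-2-methylphenyl in place of 2-fluorophenyl goes with an 8.5-fold higher number from compound 2 to compound 3 (0.93 log units; beyond the scatter) in this assay. For the compounds shown here, this is the first single-place comparison, since compound 1 and compound 2 differ in more than one place, and it shows that this carbon is not a silent spot for this read-out: the number moves well past the usual scatter, even though neither group carries hydrogen-bond donors, acceptors or charge. Nothing available here accounts for the size of this step, so the result stands as an observation without an explanation.

Going by these compounds alone, the swap bundles two differences on the phenyl ring, so a plain 4-fluorophenyl or a plain 2-methylphenyl at the same carbon would be needed to tell whether the fluorine's place, the methyl group or only the pair together goes with the higher number. From the compounds shown here alone, it also remains open whether the same step would appear with other groups at this carbon, such as a pyridyl ring or a phenyl ring carrying a carboxylic acid, or on the core of compound 1.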